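One stereoisomer left to measure at a shared limit

The source may hold more compounds than are shown below. What is called first, only, known or untested is meant among the compounds shown, and "the series" means these compounds.

Compound 1 `O=[N+]([O-])c1cn2c(n1)[S@+]([O-])C[C@H](OCc1ccc(OC(F)(F)F)cc1)C2`: > 64000 nM
Compound 2 `O=[N+]([O-])c1cn2c(n1)[S@@+]([O-])C[C@@H](OCc1ccc(OC(F)(F)F)cc1)C2`: > 64000 nM
Compound 3 `O=[N+]([O-])c1cn2c(n1)[S@@+]([O-])C[C@H](OCc1ccc(OC(F)(F)F)cc1)C2`: > 64000 nM

In an ADME assay on MRC5 cells (Homo sapiens) for cytotoxicity (on this read-out lower numbers stand for stronger inhibition and higher numbers for weaker inhibition), compound 3 gives > 64000 nM, which is a limit of the assay and not a number. It has no readable place among the three measured compounds, as all of them stand at one point: the limit of > 64000 nM in this assay, at which 3 of the 3 values shown sit.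

The remaining compound 4 `O=[N+]([O-])c1cn2c(n1)[S@+]([O-])C[C@@H](OCc1ccc(OC(F)(F)F)cc1)C2` is the mirror image of compound 3: the two compounds have the same atoms and bonds and differ only in configuration as drawn: 2 of 2 stereo elements differ (all stereocentres are inverted: mirror images); a stereocentre at a sulfur is drawn S in compound 3 and R in compound 4; a stereocentre at a saturated ring carbon is drawn R in compound 3 and S in compound 4.

The closest parallel is a step that the two limits leave unreadable from compound 1 to compound 2, also between mirror images. Two further steps, a step that the two limits leave unreadable from compound 1 to compound 3 and a step that the two limits leave unreadable from compound 2 to compound 3, each differ at one stereocentre. None of the three has a size that can be read, so they give no direction for this assay, and no step beyond the scatter is expected.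

The expected step is a number no higher from compound 3 to compound 4 (the limit leaves the size open), an estimate that rests on those unreadable steps.

Compound 4 is estimated at 64000 nM, with an expected range of 30000 nM to 128000 nM, and the assay will probably report only a limit.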

Compound 4, half-maximal inhibitory concentration: 50000 nM
Compound 4: the middle estimate sits 1.3-fold (0.11 log units) above what was measured; the range from low to high includes it.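

In this assay, among these compounds, compound 4 is the only one of the four stereoisomers to give a number and not a limit, so this is the first readable value for this configuration series. Inverting both stereocentres gives an at least 1.2-fold lower number from compound 3 to compound 4 (0.10 log units; that floor lies within the scatter), inverting the sulfur alone gives an at least 1.2-fold lower number from compound 2 to compound 4 (0.10 log units; that floor lies within the scatter), and inverting the saturated ring carbon alone gives an at least 1.2-fold lower number from compound 1 to compound 4 (0.10 log units; that floor lies within the scatter). Compounds 1, 2 and 3 each remain at a limit of the assay, and the steps among them cannot be read: the limit of > 64000 nM in this assay, at which 3 of the 4 values shown sit.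

From the compounds shown here alone, the true size of all three new steps stays open, and with it whether configuration at either stereocentre matters at all in this assay. Also open, going by these compounds, is how an amine or a carboxylic acid on the benzyl ring would read in this assay.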